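Sulfonamide series: amide variation at the para position

The source may hold more compounds than are shown below. What is called first, only, known or untested is meant among the compounds shown, and "the series" means these compounds.

- compound 1 `N#Cc1cc(NS(=O)(=O)c2ccc(NC(=O)N3CCOCC3)cc2)ccc1Oc1ccc(Cl)c(C(F)(F)F)c1`: 27%
- compound 2 `N#Cc1cc(NS(=O)(=O)c2ccc(N)cc2)ccc1Oc1ccc(Cl)c(C(F)(F)F)c1`: 33%
- compound 3 `CC(=O)Nc1ccc(S(=O)(=O)Nc2ccc(Oc3ccc(F)c(C(F)(F)F)c3)c(C#N)c2)cc1`: 23%

In an assay for inhibition of platelet-activating factor acetylhydrolase (Rattus norvegicus), in plasma, with stated times of 30 min and 10 min, tested at 50 nM (on this read-out higher numbers stand for more inhibition at the one concentration tested (going by the name of the read-out) and lower numbers for less inhibition), compound 1 gives 27%. It stands second highest of the three numbers; its nearest neighbour is compound 3 at 23%, the furthest is compound 2 at 33%, and both gaps are within the scatter, so the three measured compounds are not separated by this read-out.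

Compound 4 `CC(=O)NCc1ccc(S(=O)(=O)Nc2ccc(Oc3ccc(Cl)c(C(F)(F)F)c3)c(C#N)c2)cc1` differs from compound 1 in one place: acetamidomethyl in place of ((morpholin-4-yl)carbonyl)amino on an aromatic carbon. Among the measured compounds shown here, the only measured step that bears on this position is a number 6 percentage points higher from compound 1 to compound 2 (within the scatter), which shows that removing the whole (morpholin-4-yl)carbonyl from that nitrogen left the read-out unchanged within the scatter. Compound 3 carries an acetyl on the same nitrogen but also a different halogen on the other ring, so it differs in two places and only its value, 23%, can be set beside compound 1; that gap too is within the scatter.

Nothing measured therefore points to a change beyond the scatter at this position. For compound 4 the step expected is a number 1 percentage points higher from compound 1 to compound 4 (within the scatter), that is none beyond the scatter, and compound 4 is estimated at 28%, with a range from 15% to 42%.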

Compound 4, a percentage reported as inhibition, at one concentration (the size of the read-out at that concentration, not a potency): 51%
Compound 4: middle estimate off by 23 percentage points, on the low side; the whole stated range lies below it.
By their numbers in this assay, from the lowest: compounds 3, 1 and 2 (each within the scatter of the next); then compound 4.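

In this assay, among the compounds shown here, the group on this aromatic carbon does move the read-out, which the earlier compounds, all within the scatter of one another, did not show: acetamidomethyl in place of ((morpholin-4-yl)carbonyl)amino gives a number 24 percentage points higher from compound 1 to compound 4 (beyond the scatter) and acetamidomethyl in place of amino gives a number 18 percentage points higher from compound 2 to compound 4 (beyond the scatter) on the same core. The entering group is the same in both steps and compound 1 and compound 2 lie within the scatter of each other, so among these three compounds the rise goes with acetamidomethyl and not with the particular group it replaces. No measurement at hand accounts for the rise.

The compounds shown leave open whether the step belongs to the methylene link to the ring or to the acetyl part of the new group; an aminomethyl group and a longer chain such as acetamidoethyl at this carbon would separate the two. Also open, from the compounds shown here alone, is whether the same step holds with fluoro in place of chloro on the other ring.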